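This account rests on a few compounds, and the source may have more. Where it says the series, first, only, none or still open, it means among the compounds named here.

Measured so far, in a functional assay on MCF7 cells (Homo sapiens) for antiproliferative activity, read by MTT assay, with a stated time of 48 h; on this read-out higher numbers stand for weaker inhibition and lower numbers for stronger inhibition:
compound 1 `COc1ccc(-n2nncc2CN2C(=O)C3(C(C#N)=C(N)Oc4c3c3nc5ccccc5nc3c3ccccc43)c3ccccc32)cc1`, whose value is a limit of the assay, > 50000 nM;
compound 2 `CC(=O)Nc1ccc(-n2nncc2CN2C(=O)C3(C(C#N)=C(N)Oc4c3c3nc5ccccc5nc3c3ccccc43)c3ccccc32)cc1`, whose value is likewise a limit, > 50000 nM;
compound 3 `N#CC1=C(N)Oc2c(N)cc3nc4ccccc4nc3c2C12C(=O)N(Cc1cnnn1-c1cccc(C(F)(F)F)c1)c1ccccc12`, which gives 31600 nM.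

Among the compounds with values here, compound 3 therefore stands alone as the only compound with an actual number; the other two sit at the limit of > 50000 nM in this assay, at which 2 of the 3 values shown sit, so nothing in this set is placed below it. Compound 4 `COc1ccc(OC)c(-n2nncc2CN2C(=O)C3(C(C#N)=C(N)Oc4c(N)cc5nc6ccccc6nc5c43)c3ccccc32)c1` keeps the core of compound 3 and differs only at the group on the triazole nitrogen: 2,5-dimethoxyphenyl in place of 3-(trifluoromethyl)phenyl on an aromatic nitrogen.

Within the data shown here, only one measured step exists, and it swaps a group on an aromatic carbon of that same phenyl ring: a step that the two limits leave unreadable from compound 1 to compound 2. It says nothing about size, and neither compound 1 nor compound 2 reaches a number. Among the measured compounds shown here, the phenyl variants that carry methoxy or acetamido thus give no readable guidance, and the change to 2,5-dimethoxyphenyl has no direct precedent here. For compound 4 a step of a 1.4-fold higher number from compound 3 to compound 4 (0.15 log units; within the scatter) is expected, toward weaker inhibition, because compound 1 with its methoxy-bearing phenyl sits at > 50000 nM. Compound 4 is estimated at 45000 nM, within 15000 nM to 120000 nM.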

Compound 4, half-maximal inhibitory concentration: 28100 nM
Estimate against measurement, compound 4: 1.6-fold (0.20 log units) above, and the stated range covers the measured number.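

Within the data shown here, this is the first readable step at the group on the triazole nitrogen: a 1.1-fold lower number from compound 3 to compound 4 (0.05 log units; within the scatter). The entering and leaving groups have the same number of heavy atoms, but 2,5-dimethoxyphenyl brings two hydrogen-bond acceptors and 3-(trifluoromethyl)phenyl brings none, and this exchange still leaves the two values indistinguishable. Compound 1 and compound 2 provide no number to set beside these, and they differ from compound 3 and compound 4 in more than one place: the limit of > 50000 nM in this assay, at which 2 of the 4 values shown sit.

Going by these compounds, whether a carboxylic acid on this phenyl ring, or a butyl chain in place of the ring, would give a clearly different value remains open. No pair shown differs in the core alone, so the contribution of the core also remains unresolved.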